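The source may hold more compounds than are shown below. What is called first, only, known or untested is meant among the compounds shown, and "the series" means these compounds.

Three compounds share one core, a six-membered aromatic ring with one nitrogen carrying a 2-chlorophenyl group and a hydroxyphenyl group. Compound 1 `Oc1cccc(-c2cc(-c3ccncc3)nc(-c3ccccc3Cl)c2)c1` carries a pyridinyl group as its third substituent; in a functional assay on DU-145 cells (Homo sapiens) for cytotoxicity, read by CCK-8 assay and cell counting, with a stated time of 2 days (a lower number here means a stronger inhibitor, a higher number a weaker inhibitor), compound 1 gives "not determined" (no result reported). Compound 2 `Oc1ccc(-c2cc(-c3ccccc3)nc(-c3ccccc3Cl)c2)cc1` carries a phenyl group beside a 4-hydroxyphenyl group. Compound 3 `Oc1cccc(-c2cc(-c3ccco3)nc(-c3ccccc3Cl)c2)c1` carries a furan-2-yl group beside a 3-hydroxyphenyl group.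

In this assay compound 2 gives 2800 nM. In this assay compound 3 gives 1630 nM, the lower of the two numbers, yet the gap to compound 2 lies within the scatter, so the two cannot be ordered.

Compound 4 `Oc1cccc(-c2cc(-c3ccccc3)nc(-c3ccccc3Cl)c2)c1` differs from compound 3 by phenyl in place of furan-2-yl on an aromatic carbon; the 2-chlorophenyl and 3-hydroxyphenyl groups stay. Since compound 2, which already carries a phenyl at that place, gives 2800 nM, no step beyond the scatter is expected, in either direction. The step of a 1.5-fold higher number from compound 3 to compound 4 (0.17 log units; within the scatter) is therefore estimated to be small. Compound 4 is expected to give 2400 nM, with a range from 800 nM to 7000 nM.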

Compound 4, half-maximal inhibitory concentration: 1480 nM
Beside the measured number, compound 4's estimate is 1.6-fold (0.21 log units) above it; the range from low to high includes it.
By their numbers in this assay, from the lowest: compounds 4, 3 and 2 (each within the scatter of the next).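

In this assay, putting phenyl in place of furan-2-yl on this aromatic carbon next to the ring nitrogen gives a 1.1-fold lower number from compound 3 to compound 4 (0.04 log units; within the scatter) and so does not separate a five-membered aromatic ring with one oxygen from a six-membered aromatic ring of carbon only. The pair of compound 2 and compound 4, which differ only in the hydroxyphenyl group, gives a 1.9-fold lower number from compound 2 to compound 4 (0.28 log units; within the scatter) for 3-hydroxyphenyl in place of 4-hydroxyphenyl, so this change shows no readable difference either. No measurement at hand offers an explanation for either result.

Going by these compounds, whether an amine or a longer carbon chain at the phenyl-bearing carbon would move the number beyond the scatter remains open. So does the role of the 2-chlorophenyl group, which stays the same throughout these compounds.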